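The compounds below may be only part of what the source reports. "The series", "measured", "known", "first", "only" and "open" are said of these compounds alone.

Values in an ADME assay on microsomes from liver (Rattus norvegicus) for metabolic stability, read by LC-MS, using NADPH, at 37 degrees C; on this read-out lower numbers stand for a shorter-lived compound and higher numbers for a longer-lived compound:
- compound 1 `Cc1oc(-c2c(F)cccc2F)nc1CN1CCC(C(=O)NCCCN2C[C@H](C)C[C@H](C)C2)CC1`: 0.35 h
- compound 2 `Cc1oc(-c2c(Br)cccc2Br)nc1CN1CCC(C(=O)NCCCN2C[C@H](C)C[C@H](C)C2)CC1`: 0.035 h
- compound 3 `Cc1oc(-c2c(Cl)cccc2C(F)(F)F)nc1CN1CCC(C(=O)NCCCN2C[C@H](C)C[C@H](C)C2)CC1`: 0.03 h

Compound 3 stands with compound 2 at the short-lived end of these numbers, the gap being a 1.2-fold lower number from compound 2 to compound 3 (0.07 log units; within the scatter). Both lie well under compound 1.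

Next is compound 4 `Cc1cccc(C)c1-c1nc(CN2CCC(C(=O)NCCCN3C[C@H](C)C[C@H](C)C3)CC2)c(C)o1`, which differs from compound 3 as follows: 2,6-dimethylphenyl in place of 2-chloro-6-(trifluoromethyl)phenyl on an aromatic carbon. In words, 2,6-dimethylphenyl takes the place of 2-chloro-6-(trifluoromethyl)phenyl on an aromatic carbon.

The three measured steps all change the same group. Two are substantial, a 10-fold lower number from compound 1 to compound 2 (1.00 log units; beyond the scatter) and a 12-fold lower number from compound 1 to compound 3 (1.07 log units; beyond the scatter). Only the 2,6-difluorophenyl of compound 1 stands apart, while the two other groups give matching numbers. Among the compounds with values here, no compound with a methyl-bearing phenyl has been measured, so the expectation is loose. Compound 4 is expected to stay near compound 3 in this assay, since compound 2 and compound 3 differ by only a 1.2-fold lower number from compound 2 to compound 3 (0.07 log units; within the scatter). The estimated step, a 1.7-fold higher number from compound 3 to compound 4 (0.22 log units; within the scatter), is none beyond the scatter. For compound 4 the estimate is 0.05 h, with an expected range of 0.02 h to 0.15 h.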

Compound 4, half-life: 0.0517 h
The estimate for compound 4 lay 1.0-fold (0.01 log units) below the measured number; the range from low to high includes it.
By their numbers in this assay, from the lowest: compounds 3, 2 and 4 (each within the scatter of the next); then compound 1.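

In this assay a phenyl group bearing two methyl groups, with no halogen on it, reads like the two heavier halogen-bearing groups: the steps are a 1.7-fold higher number from compound 3 to compound 4 (0.24 log units; within the scatter) and a 1.5-fold higher number from compound 2 to compound 4 (0.17 log units; within the scatter), both printed as within the scatter. The 2,6-difluorophenyl of compound 1 therefore remains the only group apart in this set, as shown by a 6.8-fold lower number from compound 1 to compound 4 (0.83 log units; beyond the scatter), and the short half-life at this place does not depend on a halogen on the phenyl, with compound 1 as the one compound that stands outside that low cluster. Nothing measured here bears on the reason for this split.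

Open, on these data alone, is how an unsubstituted phenyl, a 2-fluoro-6-methylphenyl or a 2,6-dimethoxyphenyl would read at this place. Also open, as far as these compounds go, is whether a single fluorine on the phenyl would be enough to keep the number of compound 1.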